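The compounds below may be only part of what the source reports. "The series", "measured", "known", "first", "only" and "open" are said of these compounds alone.

Of the compounds shown here, three have so far been tested in an ADME assay on TZM-b1 cells (Homo sapiens) for cytotoxicity, read by XTT assay, with a stated time of 3 days (a lower number here means that less compound is tolerated, a higher number that more compound is tolerated), and each of them gave only a limit of the assay rather than a number.

Compound 1 `Cc1nc(C(NC(=O)C(=O)Nc2ccc(F)cc2)C2CCCCN2)sc1CCO`: in this assay compound 1 gives > 88000 nM, a limit.
Compound 2 `Cc1nc(C(NC(=O)C(=O)Nc2ccc(F)cc2F)C2CCCCN2)sc1CCO`: in this assay compound 2 gives > 84000 nM, a limit.
Compound 3 `Cc1nc(C(NC(=O)C(=O)NC2CCCCCC2)C2CCCCN2)sc1CCO`: in this assay compound 3 gives > 88000 nM, a limit.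

Compound 3 thus stands at a limit, as do the other two, and none of the three can be ranked against another. The steps a step that the two limits leave unreadable from compound 1 to compound 2, a step that the two limits leave unreadable from compound 1 to compound 3 and a step that the two limits leave unreadable from compound 2 to compound 3 bear on the change that follows, since each of them alters the group attached to the amide-type nitrogen, yet the two limits the limit of > 84000 nM in this assay, at which 1 of the 3 values shown sits, and the limit of > 88000 nM in this assay, at which 2 of the 3 values shown sit, leave their sizes unreadable. Compound 4 `CC(=O)c1ccc(NC(=O)C(=O)NC(c2nc(C)c(CCO)s2)C2CCCCN2)cc1` differs from compound 3 in one place: 4-acetylphenyl in place of cycloheptyl on an amide-type nitrogen. Because all three measured values sit at the limits the limit of > 84000 nM in this assay, at which 1 of the 3 values shown sits, and (the limit of > 88000 nM in this assay, at which 2 of the 3 values shown sit), no step beyond the scatter is expected in this assay in either direction, and the expected step of a number no higher from compound 3 to compound 4 (the limit leaves the size open) reflects that. Compound 4 is therefore estimated at 88000 nM, with a range from 30000 nM to 250000 nM, and it will most likely again be reported only as a limit.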

Compound 4, half-maximal cytotoxic concentration: > 77300 nM
Compound 4 gave a limit, no number; the forecaster's own chance of this, stated with the estimate: 80%; the middle value does not contradict the limit.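

In this assay, for the compounds shown here, compound 4 also gives only a limit, as do compound 1, compound 2 and compound 3, so no step between compound 4 and any of these three can be read: the limit of > 77300 nM in this assay, at which 1 of the 4 values shown sits.

The compounds shown leave open how much of each compound the cells tolerate, and whether changing the group on the amide-type nitrogen alters that tolerance at all.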